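The compounds below may be only part of what the source reports. "The series", "measured", "known", "first", "only" and "open" are said of these compounds alone.

Compound 1 `COc1nc(-c2ccc(F)cc2)ccc1[C@@H](c1ccccc1)[C@@](O)(CCN(C)C)c1cccc2ccccc12`: > 64 ug/mL
Compound 2 `COc1ncc(-c2ccccc2)cc1[C@@H](c1ccccc1)[C@@](O)(CCN(C)C)c1ccccc1`: 11.9 ug/mL

In a toxicity assay on HeLa cells (Homo sapiens) for cytotoxicity (on this read-out higher numbers stand for lower toxicity in this test and lower numbers for higher toxicity in this test), compound 1 gives only a limit of the assay, > 64 ug/mL, so its exact position is not known; this is the limit of > 64 ug/mL in this assay, at which 1 of the 2 values shown sits. In this assay compound 2 gives 11.9 ug/mL. Compound 3 `COc1nc(-c2ccccc2Cl)ccc1[C@@H](c1ccccc1)[C@@](O)(CCN(C)C)c1cccc2ccccc12` differs from compound 1 in one place: 2-chlorophenyl in place of 4-fluorophenyl on an aromatic carbon. Among the measured compounds shown here, no measured pair shows this change, so the step of an at least 1.0-fold lower number from compound 1 to compound 3 (0.02 log units; that floor lies within the scatter) is expected to stay within the scatter, in no particular direction. For compound 3 the estimate is 60 ug/mL, between 25 ug/mL and 120 ug/mL.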

Compound 3, half-maximal cytotoxic concentration: > 64 ug/mL
Compound 3: a limit, no number; the forecaster's own chance of this, stated with the estimate: 60%; middle value at least 1.0-fold (0.02 log units) away from the limit.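

Compound 1 and compound 3 each give only a limit in this assay, so no step between them can be read: the limit of > 64 ug/mL in this assay, at which 2 of the 3 values shown sit.

Whether 2-chlorophenyl in place of 4-fluorophenyl changes the toxicity of these compounds at all remains open.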